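A few compounds are considered here, and "the series" means these few. Any claim that something is new, unique, unknown or untested is made for them only; others in the source may bear on it.

In a functional assay on HL-60 cells (Homo sapiens) for cytotoxicity, read by MTT assay, with a stated time of 72 h (on this read-out higher numbers stand for weaker inhibition and lower numbers for stronger inhibition), the three measured compounds of this set are all weak. Compound 1 `Fc1ccc(-c2nnc3nnc(N4CCCCC4)nn23)cc1` gives 30700 nM, and compound 2 `CC(C)c1nnc2nnc(N3CCCC3)nn12` gives 71200 nM, the higher of the two numbers recorded; the gap between compound 2 and compound 1 lies beyond the usual scatter. Compound 3 `O=[N+]([O-])c1ccc(-c2nnc3nnc(N4CCCC4)n3n2)cc1` reaches only the limit of the assay, > 100000 nM, and no number is given for it, so that the limit of > 100000 nM in this assay, at which 1 of the 3 values shown sits, describes where one of the three values sits.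

Compound 4 `C1CCC(c2nnc3nnc(N4CCCC4)nn23)CC1` has not yet been measured. It differs from compound 2 in a single place: cyclohexyl in place of isopropyl on an aromatic carbon. The shared core and the pyrrolidine ring are kept, and the change is confined to the group on the aromatic carbon between two ring nitrogen atoms.

No measured pair in this set differs by such a change, so nothing shown tells how this assay responds to it. In this assay compound 4 is expected to give a number close to that of compound 2, with the step of a 1.4-fold lower number from compound 2 to compound 4 (0.15 log units; within the scatter) expected to stay within the scatter. Compound 4 is estimated at 50000 nM, with a range from 15000 nM to 150000 nM.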

Compound 4, half-maximal inhibitory concentration: 23800 nM
For compound 4 the middle estimate is 2.1-fold (0.32 log units) above the measured one, and the stated range covers the measured number.
By their numbers in this assay, from the lowest: compounds 4 and 1 (each within the scatter of the next); then compound 2. At a limit, above all of these: compound 3.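

With the shared core and the pyrrolidine ring kept, cyclohexyl in place of isopropyl gives a 3.0-fold lower number from compound 2 to compound 4 (0.48 log units; beyond the scatter) in this assay. Within the data shown here, this is the first step in the set between compounds that differ in one place, and it shows that the number responds to the group on this aromatic carbon, between two ring nitrogen atoms. The data shown give no reason for the step.

A single step cannot say whether the ring itself or the larger count of carbon atoms goes with the lower number. On these data alone, how an open hexyl chain, or a cyclohexyl ring carrying an amine or a carboxylic acid, would read at this place remains open, as does whether the step holds with a ring other than pyrrolidine on the shared core.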